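The source may report more compounds than this note shows. Statements on the series, on what has been measured and on what is new or still open speak of the compounds shown alone.

In a functional assay on Bel-7402 cells (Homo sapiens) for inhibition, read by MTT assay, with a stated time of 24 h, tested at 10 ug/mL (a higher number here means more inhibition of growth at the concentration tested, a lower number less inhibition of growth), compound 1 (`O=C(CCCCC1CCSS1)Nc1ccc(Cl)cn1`) gives 16.1% and compound 2 (`O=C(CCCCC1CCSS1)Nc1ccc(Br)cn1`) gives 24.5%. These two values lie within the scatter of each other, so the numbers do not separate compound 2 from compound 1. Compound 3 (`O=C(CCCCC(S)CCS)Nc1ccc(Br)cn1`) differs from compound 2 in one place: a group of 5 heavy atoms (3 carbon, 2 sulfur; no ring) in place of a group of 5 heavy atoms (3 carbon, 2 sulfur; one five-membered non-aromatic ring with 2 hetero atoms), on a saturated chain carbon, four bonds along the chain from a carbonyl carbon. For the measured compounds named here, the only measured step, a number 8.4 percentage points higher from compound 1 to compound 2 (within the scatter), is bromo in place of chloro on an aromatic carbon, and it lies within the scatter. That step does not touch the group that changes here, so the data offer no measured size or direction for this change. With nothing pointing either way, this assay is expected to show no shift beyond the scatter, and the expected step, a number 2.5 percentage points higher from compound 2 to compound 3 (within the scatter), is only a tentative estimate. The estimate for compound 3 is 27%, with an expected range of 10% to 48%.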

Compound 3, percent growth inhibition at one concentration: 23.2%
Compound 3: the middle estimate sits 3.8 percentage points above what was measured; the measured number falls inside the stated range.
By their numbers in this assay, from the lowest: compounds 1, 3 and 2 (each within the scatter of the next).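

In this assay, for the compounds shown here, the change from the five-membered ring of compound 2 to the open 1,3-disulfanylpropyl group of compound 3 gives a number 1.3 percentage points lower from compound 2 to compound 3 (within the scatter) and so supplies the first measured step at this position on the saturated chain. With the bromo group held in place, the closed ring and the open group, which adds hydrogen-bond donors, are not separated by this read-out, so the ring is not shown to be required for the growth inhibition seen here. No measurement at hand accounts for this result.

As far as these compounds go, whether the open group behaves the same way alongside the chloro group of compound 1 remains open. So does the outcome of placing a different group on this chain carbon, such as a carboxylic acid or an amine.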